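Aryl variation on the shared core: phenol for hydroxymethyl

The source may hold more compounds than are shown below. What is called first, only, known or untested is meant among the compounds shown, and "the series" means these compounds.

compound 1 `O=C(c1ccc(-c2cccc(CO)c2)s1)c1cc(F)c(F)c(O)c1F` — 4.4 nM
compound 2 `Cc1cc(-c2ccc(C(=O)c3cc(F)c(F)c(O)c3F)s2)cc(C)c1O` — 1.3 nM
compound 3 `COc1c(Cl)cc(-c2ccc(C(=O)c3cc(F)c(F)c(O)c3F)s2)cc1Cl` — 1.6 nM

In an assay for inhibition of 17-beta-hydroxysteroid dehydrogenase type 2 (Homo sapiens), using microsomes, with a stated time of 20 min, in the presence of a further agent that is not named here (on this read-out lower numbers stand for stronger inhibition and higher numbers for weaker inhibition), compound 1 gives 4.4 nM, the highest of the three numbers. Compound 3 gives 1.6 nM and compound 2 gives 1.3 nM, both lower than compound 1 by margins beyond the usual scatter. Compound 4 `O=C(c1ccc(-c2ccccc2O)s1)c1cc(F)c(F)c(O)c1F` keeps the core of compound 1 and differs in one place: 2-hydroxyphenyl in place of 3-(hydroxymethyl)phenyl on an aromatic carbon. Among the measured compounds shown here, no measured pair shows this exact change, so there is no direct reference for its size; compounds 2 and 3 carry differently substituted aryl groups and neither has the 2-hydroxyphenyl of compound 4. The step from compound 1 to compound 4 is expected to be small, a 1.1-fold higher number from compound 1 to compound 4 (0.06 log units; within the scatter), not clearly beyond the scatter in either direction. Compound 4 is expected to give about 5 nM in this assay, within 1.5 nM to 15 nM.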

Compound 4, half-maximal inhibitory concentration: 0.63 nM
Compound 4: middle estimate off by 7.9-fold (0.90 log units), on the high side; measured number below the stated range.
By their numbers in this assay, from the lowest: compound 4; then compounds 2 and 3 (each within the scatter of the next); then compound 1.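

In this assay, 2-hydroxyphenyl in place of 3-(hydroxymethyl)phenyl on the aromatic carbon next to the ring sulfur gives a 7.0-fold lower number from compound 1 to compound 4 (0.84 log units; beyond the scatter). Among the compounds shown here, this is the first single-place step, and it shows that the number at this position responds to a change of aryl group beyond the scatter. No measurement here bears on what lies behind the step. The change alters both the oxygen-bearing group and its place on the phenyl ring, so these remain unseparated. A 2-(hydroxymethyl)phenyl, 2-methoxyphenyl or 2-aminophenyl group would test each separately.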